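The compounds below may be only part of what the source reports. "The series", "measured", "known", "first", "only" and "open" are said of these compounds alone.

Three compounds share one core and differ only in the group attached to the carbonyl carbon of the sulfonyl-bearing carbamate. In an assay on HEK293 cells for displacement of a labelled ligand from Type-2 angiotensin II receptor (Homo sapiens), read by scintillation counting, with a stated time of 240 min (a higher number here means a weaker inhibitor, a lower number a stronger inhibitor), compound 1 `CCOC(=O)NS(=O)(=O)c1sc(CC(C)C)cc1-c1cccc(Cn2ccnc2)c1` gives 300 nM, compound 2 `CC(C)Cc1cc(-c2cccc(Cn3ccnc3)c2)c(S(=O)(=O)NC(=O)OC2CCCC2)s1` gives 180 nM, and compound 3 `COCCOC(=O)NS(=O)(=O)c1sc(CC(C)C)cc1-c1cccc(Cn2ccnc2)c1` gives 480 nM. Compound 3 therefore carries the highest number of the three: the step of a 1.6-fold higher number from compound 1 to compound 3 (0.20 log units; within the scatter) stays within the scatter, whereas a 2.7-fold higher number from compound 2 to compound 3 (0.43 log units; beyond the scatter) reaches beyond it.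

Compound 4 `CCN(CC)C(=O)NS(=O)(=O)c1sc(CC(C)C)cc1-c1cccc(Cn2ccnc2)c1` is made from compound 3 by the change (diethylamino in place of 2-methoxyethoxy on a carbonyl carbon). The steps measured so far all exchange one group on the oxygen next to the carbonyl for another: a 1.7-fold lower number from compound 1 to compound 2 (0.22 log units; within the scatter), a 1.6-fold higher number from compound 1 to compound 3 (0.20 log units; within the scatter) and a 2.7-fold higher number from compound 2 to compound 3 (0.43 log units; beyond the scatter). For the measured compounds named here, none of them replaces that oxygen with a nitrogen, so the present step has no direct precedent; the changes at this carbonyl that were measured stayed small, and nothing among them points to a large move in either direction. Compound 4 is therefore expected to give about 350 nM in this assay, in a range from 120 nM to 1000 nM, which would mean an expected step of a 1.4-fold lower number from compound 3 to compound 4 (0.14 log units; within the scatter).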

Compound 4, inhibition constant: 2300 nM
Compound 4: the middle estimate sits 6.6-fold (0.82 log units) below what was measured; measured number above the stated range.
By their numbers in this assay, from the lowest: compounds 2, 1 and 3 (each within the scatter of the next, the first and the last beyond it); then compound 4.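

With diethylamino on the carbonyl carbon, the number rises well beyond the scatter against every oxygen-linked group in this assay: the change gives a 4.8-fold higher number from compound 3 to compound 4 (0.68 log units; beyond the scatter) and a 7.7-fold higher number from compound 1 to compound 4 (0.88 log units; beyond the scatter) and also a 13-fold higher number from compound 2 to compound 4 (1.11 log units; beyond the scatter) and so compound 4 is the weakest inhibitor of the four. The position therefore responds far more to this exchange than to the swaps among ethoxy, cyclopentyloxy and 2-methoxyethoxy, even though 2-methoxyethoxy and diethylamino both count 5 heavy atoms. Nothing available explains this result.

On these data alone, whether the rise goes with the nitrogen itself or with its two ethyl groups stays open. An ethylamino or cyclopentylamino group on the same carbonyl carbon would separate those two readings.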